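Swapping a sulfonamide for a pyridylmethyl amine on the piperidine

A few compounds are considered here, and "the series" means these few. Any claim that something is new, unique, unknown or untested is made for them only; others in the source may bear on it.

Compound 1 `CN(C1CCN(CCCc2c[nH]c3ccc(-n4cnnc4)cc23)CC1)S(=O)(=O)c1ccccc1` is the strongest binder among the three measured here. In an assay on CHO cells for displacement of a labelled ligand from 5-hydroxytryptamine receptor 1D (Homo sapiens) (on this read-out lower numbers stand for stronger inhibition and higher numbers for weaker inhibition), compound 1 gives 1.5 nM, the lowest number of the set. Compound 2 `CN(Cc1ccc(S(C)(=O)=O)cc1)C1CCN(CCCc2c[nH]c3ccc(-n4cnnc4)cc23)CC1` gives 18 nM and compound 3 `CC(=O)Nc1ccc(CN(C)C2CCN(CCCc3c[nH]c4ccc(-n5cnnc5)cc34)CC2)cc1` gives 19 nM; both carry a benzyl-type group in place of the phenylsulfonyl on the amine nitrogen, and both steps away from compound 1 are large: a 12-fold higher number from compound 1 to compound 2 (1.08 log units; beyond the scatter) and a 13-fold higher number from compound 1 to compound 3 (1.10 log units; beyond the scatter). Between the two benzyl analogues the change is small, a 1.1-fold higher number from compound 2 to compound 3 (0.02 log units; within the scatter).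

Compound 4 `c1cncc(CNC2CCN(CCCc3c[nH]c4ccc(-n5cnnc5)cc34)CC2)c1` has not yet been measured. It differs from compound 1 in one place: ((pyridin-3-yl)methyl)amino in place of methyl(phenylsulfonyl)amino on a saturated ring carbon. As in the two measured steps, the phenylsulfonyl on the amine nitrogen is replaced by an aromatic methyl group, so a loss of similar size is expected; the methyl on the nitrogen is also gone, which the measured compounds do not address. For compound 4 the expected step is a 13-fold higher number from compound 1 to compound 4 (1.12 log units; beyond the scatter), giving an estimate of 20 nM with a range from 5 nM to 80 nM.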

Compound 4, half-maximal inhibitory concentration: 35 nM
Compound 4: the middle estimate sits 1.8-fold (0.24 log units) below what was measured; the measured number falls inside the stated range.
By their numbers in this assay, from the lowest: compound 1; then compounds 2, 3 and 4 (each within the scatter of the next).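

In this assay this swap gives a 23-fold higher number from compound 1 to compound 4 (1.37 log units; beyond the scatter) and so adds a third large step away from compound 1, this time with a pyridine-type ring carrying one hetero atom instead of a ring of carbon only. Among the compounds shown, every replacement of the methyl(phenylsulfonyl)amino group on this saturated ring carbon gives a higher number than compound 1, and none goes against this. Unlike the two earlier changes, this one also removes the methyl from the amine nitrogen and leaves a hydrogen there, so several changes are bundled into a single step.

Nothing available explains why the number rises.

A phenylsulfonylamino group without the methyl, or a methyl((pyridin-3-yl)methyl)amino group, could show how much of the step belongs to that methyl and how much to the loss of the sulfonyl.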